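The compounds below may be only part of what the source reports. "The series", "measured", "known", "first", "only" and "open" are said of these compounds alone.

The compounds measured so far:

Compound 1, `O=C(O)Cc1sc(C(c2ccc(F)cc2)c2ccc(F)cc2)nc1-c1ccnc(N2CCC2)c1`, in an in vitro functional assay on HEK285-7 cells for antagonist activity at prostaglandin D2 receptor 2 (Homo sapiens), read by BRET and beta-arrestin recruitment (a higher number here means a weaker inhibitor, a lower number a stronger inhibitor), gives > 100000 nM, which is a limit of the assay and not a number.

Compound 2, `O=C(O)Cc1sc(C(c2ccc(F)cc2)c2ccc(F)cc2)nc1-c1ccoc1`, in this assay gives 130 nM.

Compound 3, `NS(=O)(=O)c1ccc(-c2nc(C(c3ccc(F)cc3)c3ccc(F)cc3)sc2CC(=O)O)cc1`, in this assay gives > 100000 nM, again a limit of the assay rather than a number.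

All three share the same core and differ only in the aromatic group attached to one of its carbons. Compound 3 therefore stands at the top of what the assay can report: the limit of > 100000 nM in this assay, at which 2 of the 3 values shown sit. Compound 4, `N#Cc1ccc(-c2nc(C(c3ccc(F)cc3)c3ccc(F)cc3)sc2CC(=O)O)cc1`, differs from compound 3 by cyano in place of sulfamoyl on an aromatic carbon.

Going by the values given here, no measured step swaps one substituent on this phenyl ring for another. The steps that touch the same spot are an at least 760-fold lower number from compound 1 to compound 2 (2.88 log units; beyond the scatter) and an at least 760-fold higher number from compound 2 to compound 3 (2.88 log units; beyond the scatter), both large, while a step that the two limits leave unreadable from compound 1 to compound 3. Together they show that the aromatic group at this position moves the number strongly, but they give no direction for a smaller substituent kept on the same phenyl ring.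

Compound 4 is accordingly expected, with low confidence, to give about 30000 nM, somewhere between 3000 nM and 100000 nM. That expectation corresponds to an at least 3.3-fold lower number from compound 3 to compound 4 (0.52 log units; beyond the scatter), with a real chance that the assay once more reports only a limit.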

Compound 4, half-maximal inhibitory concentration: 1500 nM
For compound 4 the middle estimate is 20-fold (1.30 log units) above the measured one, outside the stated range (below it).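

In this assay, the phenyl ring stays in place and only its substituent, para to a large group, changes, yet cyano in place of sulfamoyl gives an at least 66-fold lower number from compound 3 to compound 4 (1.82 log units; beyond the scatter), so this one substituent can decide whether the assay returns a number at all. The phenyl ring is therefore compatible with measurable activity at this position, and the 4-cyanophenyl group also compares well with the 2-(azetidin-1-yl)pyridin-4-yl group, with an at least 66-fold lower number from compound 1 to compound 4 (1.82 log units; beyond the scatter), though it does not match furan-3-yl, with a 12-fold higher number from compound 2 to compound 4 (1.06 log units; beyond the scatter). Compound 1 and compound 3 both rest at a limit of the assay, not a number, so no step between them can be read: the limit of > 100000 nM in this assay, at which 2 of the 4 values shown sit.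

Only two substituents on this phenyl ring are shown, so it stays open how an unsubstituted phenyl ring, or one carrying a fluorine atom, a methoxy group or a carboxylic acid, would compare with compound 4. The compounds shown also do not tell whether any substituent on a phenyl ring, such as an amine or a longer chain ending in a nitrile, could close the remaining gap to compound 2.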